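The source may hold more compounds than are shown below. What is called first, only, known or untested is meant among the compounds shown, and "the series" means these compounds.

Three related compounds have been measured in a functional assay on T47D cells (Homo sapiens) for cytotoxicity, read by CCK-8 assay; on this read-out higher numbers stand for weaker inhibition and lower numbers for stronger inhibition. Compound 1 `Oc1cccc(-c2cc(-c3ccoc3)cc(-c3cccc(O)c3)n2)c1` gives 2590 nM. Compound 2 `Oc1ccc(-c2cc(-c3ccoc3)cc(-c3cccc(O)c3)n2)cc1` carries the change (4-hydroxyphenyl in place of 3-hydroxyphenyl on an aromatic carbon), and in this assay compound 2 gives 2610 nM. That change made the step of a 1.0-fold higher number from compound 1 to compound 2 (0.00 log units; within the scatter), so the two numbers cannot be told apart. Compound 3 `Oc1cccc(-c2cc(-c3ccccn3)cc(-c3ccccc3O)n2)c1` is built on a different core; how its core differs from the core of compound 1 is not broken down here. In this assay compound 3 gives 2560 nM, a number that sits together with those of compound 1 and compound 2, so none of the three can be called stronger or weaker than the others.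

Compound 4 `Oc1ccc(-c2cc(-c3ccccn3)cc(-c3ccccc3O)n2)cc1` has not yet been measured. It differs from compound 3 by 4-hydroxyphenyl in place of 3-hydroxyphenyl on an aromatic carbon. Within the data shown here, this is the same kind of change as the one made on compound 1, but the surroundings are not identical: in compound 1 the place is meta to a 3-hydroxyphenyl group and meta to a furan-3-yl group, whereas in compound 3 it is meta to a 2-hydroxyphenyl group and meta to a pyridin-2-yl group.

Compound 4 is expected to show a step of a 1.0-fold higher number from compound 3 to compound 4 (0.01 log units; within the scatter), an expectation resting on the measured step of a 1.0-fold higher number from compound 1 to compound 2 (0.00 log units; within the scatter) having stayed within the scatter. In this assay compound 4 is therefore estimated at 2600 nM, with a likely range from 1300 nM to 5200 nM.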

Compound 4, half-maximal inhibitory concentration: > 50000 nM
Compound 4: only a limit was reported (the forecaster's own chance of this, stated with the estimate: 5%); at least 19-fold (1.28 log units) between middle value and limit.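

In this assay compound 4 reads > 50000 nM, which is a limit of the assay and not a number. Putting 4-hydroxyphenyl in place of 3-hydroxyphenyl on this core gave an at least 19-fold higher number from compound 3 to compound 4 (1.29 log units; beyond the scatter), so the near absence of any effect seen on the other core did not carry over: the same change on two cores in this assay, a 1.0-fold higher number (0.00 log units; within the scatter) from compound 1 to compound 2 and an at least 19-fold higher number (1.29 log units; beyond the scatter) from compound 3 to compound 4, at least 19-fold (1.28 log units) apart, beyond the scatter of two such steps This shows that, for these two pairs, the result of the change depends on the core it is made on, and that a flat step on one core is no safe guide to the same step on a related core, but it does not show which feature of the cores is responsible, and the limit leaves the full size of the step unknown.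

The cores differ in two groups, furan-3-yl against pyridin-2-yl and 3-hydroxyphenyl against 2-hydroxyphenyl, and a core pairing furan-3-yl with 2-hydroxyphenyl, or pyridin-2-yl with 3-hydroxyphenyl, would be needed to tell these two differences apart. As far as these compounds go, it also remains open whether the hydroxyl itself matters for the loss on compound 4, which a methoxy group or an amine in its place on the 4-hydroxyphenyl ring could test.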